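Three measured compounds and a fourth awaiting its number

This account rests on a few compounds, and the source may have more. Where it says the series, first, only, none or still open, it means among the compounds named here.

The series contains three measured compounds and one that has not yet been tested. Compound 1 `Cc1cc(=O)c2c(O)cc(O)c([C@H]3CCN(C)C[C@H]3OC(=O)c3ccco3)c2o1`, compound 2 `Cc1cc(=O)c2c(O)c(CN3CCCCC3)c(O)c([C@H]3CCN(C)C[C@H]3O)c2o1` and compound 3 `Cc1oc2c([C@H]3CCN(C)C[C@H]3O)c(O)cc(O)c2c(=O)c1C(O)c1ccc(Cl)cc1` share a common core and were all examined in a functional assay on PC-3 cells (Homo sapiens) for inhibition, read by MTT assay, with a stated time of 48 h, tested at 10 uM; on this read-out higher numbers stand for more inhibition of growth at the one concentration tested and lower numbers for less inhibition of growth. In this assay compound 1 gives 23%, compound 2 gives 14% and compound 3 gives 41%. Compound 3 therefore stands highest of the three numbers: its gap to compound 1 lies beyond the scatter, and its gap to compound 2 lies beyond the scatter as well, so compound 3 can be called the most active of the three in this assay.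

Compound 4 `CCOc1ccc(Br)c(C(O)c2c(C)oc3c([C@H]4CCN(C)C[C@H]4O)c(O)cc(O)c3c2=O)c1` differs from compound 3 in a single place: 2-bromo-5-ethoxyphenyl in place of 4-chlorophenyl on a saturated chain carbon bound to an aromatic carbon and an oxygen on a saturated carbon. Within the data shown here, no pair among the measured compounds shows a change of this kind, so there is no measured step that would indicate a direction. The expectation is that the step in this assay is a number 3 percentage points lower from compound 3 to compound 4 (within the scatter), which is small and would not reach beyond the scatter in either direction. For compound 4 the estimated growth inhibition in this assay is 38%, with a range from 18% to 60%.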

Compound 4, percent growth inhibition at one concentration: 0%
Beside the measured number, compound 4's estimate is 38 percentage points above it; the measured number lies below the stated range.
By their numbers in this assay, from the lowest: compound 4; then compounds 2 and 1 (each within the scatter of the next); then compound 3.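

In this assay, among these compounds, the step of a number 41 percentage points lower from compound 3 to compound 4 (beyond the scatter) is the first measured change that differs in one place, and it shows that the group on a saturated chain carbon bound to an aromatic carbon and an oxygen on a saturated carbon strongly affects the read-out. The activity seen with 4-chlorophenyl does not carry over to 2-bromo-5-ethoxyphenyl, even though both groups contain one six-membered aromatic ring of carbon only, so the presence of such a ring at this position is not enough to keep the growth inhibition of compound 3. Nothing measured here explains why this single change has so large an effect.

The step exchanges chlorine for bromine, moves the halogen and adds an ethoxy group all at once, so the compounds shown leave open which of these parts accounts for the drop. A 4-bromophenyl, a 2-chlorophenyl or a 3-ethoxyphenyl group at the same place would separate these parts, and an unsubstituted phenyl group would show what the 4-chloro substituent itself contributes.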